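The compounds below may be only part of what the source reports. "The series", "measured", "known", "first", "only" and "open" are said of these compounds alone.

Measured compounds:
compound 1 `COc1ccc2nc(C(=O)Nc3ccc(-c4ccccc4)cc3)c(C)c(O)c2c1` — 7.58%
compound 2 `Cc1c(C(=O)Nc2ccc(-c3ccccc3)cc2)nc2ccccc2c1O` — 9.34%

In a functional assay on Hep 3B2 cells (Homo sapiens) for antiproliferative activity, read by MTT assay, with a stated time of 24 h, tested at 0.41 ug/mL (a higher number here means a stronger effect of the compound at the concentration tested, a lower number a weaker effect), compound 1 gives 7.58%, the lowest of the two numbers. Among the measured compounds shown here, the only measured step, a number 1.8 percentage points higher from compound 1 to compound 2 (within the scatter), does not separate the two compounds, and compound 2 gives 9.34%.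

Compound 3 `COc1ccc2nc(C(=O)Nc3ccc(-c4ccccc4)cc3)c(C)c(C(=O)O)c2c1` differs from compound 1 by carboxy in place of hydroxy on an aromatic carbon. For the measured compounds named here, no measured step concerns this change: the single step in hand exchanges hydrogen for methoxy at another aromatic carbon and stays within the scatter, so it neither supports nor excludes a shift here. Both measured numbers are low and close together. With nothing pointing in either direction, compound 3 is expected to remain near compound 1, the expected step being a number 1.4 percentage points higher from compound 1 to compound 3 (within the scatter), none beyond the scatter. Compound 3 is therefore estimated at 9%, between 0% and 25%.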

Compound 3, a percentage reported as inhibition, at one concentration (the size of the read-out at that concentration, not a potency): 5.31%
For compound 3 the middle estimate is 3.7 percentage points above the measured one, and the stated range covers the measured number.
By their numbers in this assay, from the lowest: compounds 3, 1 and 2 (each within the scatter of the next).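

In this assay, among the compounds shown here, carboxy in place of hydroxy on the aromatic carbon opposite the ring nitrogen gives a number 2.3 percentage points lower from compound 1 to compound 3 (within the scatter), the first step at this position. Compounds 1 and 2 both carry hydroxy here, so they could not show that a group of 3 heavy atoms, in place of 1, can stand ortho to the methyl group without a step beyond the scatter. No measurement available explains why the two groups read alike.

Going by these compounds, it remains open whether an amine or a methyl ester at this position would give a number beyond the scatter of compound 1. Also open is whether carboxy reads alike on the core of compound 2, and how any of these compounds behave at other concentrations.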